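Glucagon receptor series: phenyl in place of trifluoromethyl

The source may hold more compounds than are shown below. What is called first, only, known or untested is meant among the compounds shown, and "the series" means these compounds.

Measured so far:
compound 1 `CCCCCc1c(C(C)C)nc(C(C)C)c(CO)c1-c1ccc(CC)cc1` 42%
compound 2 `CCCCCc1c(C(C)C)nc(C(C)C)c(CO)c1-c1ccc(C(C)C)cc1` 34%
compound 3 `CCCCCc1c(C(C)C)nc(C(C)C)c(CO)c1-c1ccc(C(F)(F)F)cc1` 35%

In an assay on CHO cells for inhibition of Glucagon receptor (Homo sapiens), tested at 20 uM (on this read-out lower numbers stand for less inhibition and higher numbers for more inhibition at the one concentration tested (going by the name of the read-out)), compound 3 sits second highest of the three, with compound 2 nearest: a number 1 percentage points higher from compound 2 to compound 3 (within the scatter). Against compound 1 the gap is a number 7 percentage points lower from compound 1 to compound 3 (within the scatter). All three numbers lie within the scatter of one another.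

Compound 4 `CCCCCc1c(C(C)C)nc(C(C)C)c(CO)c1-c1ccc(-c2ccccc2)cc1` differs from compound 3 in one place: phenyl in place of trifluoromethyl on an aromatic carbon. Going by the values given here, the steps that bear on this place, a number 7 percentage points lower from compound 1 to compound 3 (within the scatter) and a number 1 percentage points higher from compound 2 to compound 3 (within the scatter), both changed the group on the same aromatic carbon and both stayed within the scatter. Among the compounds with values here, no step brings in a ring at this place. A step within the scatter is therefore expected in this assay, with no direction claimed: no change at the digits printed from compound 3 to compound 4 (within the scatter). Compound 4 is estimated at 35%, range 20% to 52%.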

Compound 4, a percentage reported as inhibition, at one concentration (the size of the read-out at that concentration, not a potency): 2%
The estimate for compound 4 lay 33 percentage points above the measured number; measured number outside the range, below it.
By their numbers in this assay, from the lowest: compound 4; then compounds 2, 3 and 1 (each within the scatter of the next).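

In this assay, ethyl, isopropyl and trifluoromethyl on this aromatic carbon stay within the scatter of one another, but phenyl does not: a number 33 percentage points lower from compound 3 to compound 4 (beyond the scatter), a number 32 percentage points lower from compound 2 to compound 4 (beyond the scatter) and a number 40 percentage points lower from compound 1 to compound 4 (beyond the scatter). Among these four compounds, only compound 4 carries a ring at this place, and it alone stands apart. Nothing measured here explains the drop. From the compounds shown here alone, whether it goes with the aromatic ring or simply with the larger count of heavy atoms stays open. A cyclohexyl ring, a pyridine ring or a longer chain such as butyl at this carbon would separate these readings.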